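The source may report more compounds than this note shows. Statements on the series, on what has been measured and on what is new or still open speak of the compounds shown alone.

Among the measured compounds shown here, compound 3 `O=C(/C=C/c1cccs1)Nc1ccc2ncnc(Nc3cccc(Br)c3)c2c1` gives 2.51 ug/mL in a functional assay on B16-F10 cells (Mus musculus) for inhibition, read by MTT assay, with a stated time of 48 h (on this read-out higher numbers stand for weaker inhibition and lower numbers for stronger inhibition), the second highest of the three numbers so far; compound 1 `O=C(/C=C/c1ccccc1)Nc1ccc2ncnc(Nc3cccc(Br)c3)c2c1` is nearest with 1.45 ug/mL, and compound 2 `O=C(/C=C/c1ccc(Br)cc1)Nc1ccc2ncnc(Nc3cccc(Br)c3)c2c1` furthest with 10.7 ug/mL. Compound 4 `Cc1ccc(/C=C/C(=O)Nc2ccc3ncnc(Nc4cccc(Br)c4)c3c2)cc1` differs from compound 3 by 4-methylphenyl in place of thiophen-2-yl on a double-bonded chain carbon bound to a double-bonded chain carbon. For the measured compounds named here, two measured steps bear on it: a 1.7-fold higher number from compound 1 to compound 3 (0.24 log units; within the scatter) shows phenyl and thiophen-2-yl at this place interchangeable within the scatter, while a 4.3-fold lower number from compound 2 to compound 3 (0.63 log units; beyond the scatter) and a 7.4-fold higher number from compound 1 to compound 2 (0.87 log units; beyond the scatter) show that 4-bromophenyl here raises the number modestly. Since 4-methylphenyl resembles 4-bromophenyl more than plain phenyl, a modest rise beyond the scatter, a 2.0-fold higher number from compound 3 to compound 4 (0.30 log units; within the scatter), is expected for compound 4, giving an estimated 5 ug/mL with a range from 1.8 ug/mL to 14 ug/mL.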

Compound 4, half-maximal inhibitory concentration: 1.39 ug/mL
Estimate against measurement, compound 4: 3.6-fold (0.56 log units) above; measured number outside the range, below it.
By their numbers in this assay, from the lowest: compounds 4, 1 and 3 (each within the scatter of the next); then compound 2.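

In this assay the 4-methylphenyl group falls in with thiophen-2-yl and plain phenyl at this place, with a 1.8-fold lower number from compound 3 to compound 4 (0.26 log units; within the scatter) and a 1.0-fold lower number from compound 1 to compound 4 (0.02 log units; within the scatter) both within the scatter. A group added to the phenyl therefore need not raise the number, and a 7.7-fold lower number from compound 2 to compound 4 (0.89 log units; beyond the scatter) leaves compound 2 as the only one of the four standing apart. Nothing at hand explains why bromo and methyl part here.

Still open, as far as these compounds go, is whether an amine or a carboxylic acid in place of that methyl would follow methyl or bromo.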